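The compounds below may be only part of what the source reports. "The series", "measured", "known", "first", "only" and "open" are said of these compounds alone.

- compound 1 `CN(C)c1ccc(/C=C(/SCc2ccc(Cl)cc2)C(=O)c2ccc(C(=O)O)cc2)cc1`: 1000 nM
- compound 2 `COc1ccc(/C=C(/SCc2ccc(Cl)cc2)C(=O)c2ccc(C(=O)O)cc2)cc1`: 10000 nM
- compound 3 `O=C(O)c1ccc(C(=O)/C(=C\c2ccc(F)c([N+](=O)[O-])c2)SCc2ccc(Cl)cc2)cc1`: 50000 nM

These values come from a functional assay on DU-145 cells (Homo sapiens) for inhibition, read by trypan blue exclusion, with a stated time of 96 h; on this read-out higher numbers stand for weaker inhibition of growth and lower numbers for stronger inhibition of growth. Compound 1 has the lowest number of the three, so it inhibits growth most strongly. Compound 4 `CN(C)c1ccc(/C=C(\C(=O)c2ccc(C(=O)O)cc2)S(=O)(=O)Cc2ccc(Cl)cc2)cc1` carries (4-chlorobenzyl)sulfonyl in place of (4-chlorobenzyl)sulfanyl ((4-chlorobenzyl)sulfonyl in place of (4-chlorobenzyl)sulfanyl on a double-bonded chain carbon bound to a carbonyl carbon and a double-bonded chain carbon). Among the compounds with values here, no measured step touches this group, so the data give only indirect guidance. Changes elsewhere gave a 10-fold higher number from compound 1 to compound 2 (1.00 log units; beyond the scatter) and a 50-fold higher number from compound 1 to compound 3 (1.70 log units; beyond the scatter), showing that single changes can matter here. Both of these steps start from compound 1 and go upward, so a modest rise seems likelier than a fall. The expected step is a 3.0-fold higher number from compound 1 to compound 4 (0.48 log units; beyond the scatter), though this is uncertain. For compound 4 the estimated value is 3000 nM, with an expected range of 500 nM to 20000 nM.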

Compound 4, concentration for 50% growth inhibition: > 100000 nM
Compound 4 ended at the assay's limit; the forecaster's own chance of this, stated with the estimate: 10%; middle value at least 33-fold (1.52 log units) from the limit.
By their numbers in this assay, from the lowest: compound 1; then compound 2; then compound 3. At a limit, above all of these: compound 4.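

The earlier steps shown here changed only the aromatic group, and this one shows that the sulfur-bearing group matters too: (4-chlorobenzyl)sulfonyl in place of (4-chlorobenzyl)sulfanyl gives an at least 100-fold higher number from compound 1 to compound 4 (2.00 log units; beyond the scatter). In this assay, compound 4 gives > 100000 nM, which is a limit of the assay and not a number. This single change at the double-bonded chain carbon therefore moves the number further than either aromatic change did.

Going by these compounds, whether a (4-chlorobenzyl)sulfinyl group here would keep the growth inhibition of compound 1 stays open. So does whether the sulfonyl group has the same effect alongside the methoxy group of compound 2.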